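Nitro to methoxy on the aryl of compound 1

The source may report more compounds than this note shows. Statements on the series, on what has been measured and on what is new or still open speak of the compounds shown alone.

The series rests on a shared core, seen in compound 1 `COc1cc(C2CC(c3ccc([N+](=O)[O-])cc3)=NN2C(C)=O)ccc1OCc1cn(Cc2ccc([N+](=O)[O-])cc2)nn1` and compound 2 `CC(=O)N1N=C(c2ccc(OCc3cn(Cc4ccc([N+](=O)[O-])cc4)nn3)cc2)CC1c1ccccc1`. In a functional assay on THP-1 cells (Homo sapiens) for inhibition, read by sulforhodamine B assay, tested at 100 uM (a higher number here means more inhibition of growth at the concentration tested, a lower number less inhibition of growth), compound 1 gives 59%, the highest of the two numbers in hand. Within the data shown here, compound 2 gives 22% in this assay, a number lower than that of compound 1 by an amount beyond the scatter; the two structures differ in more than one place, so no single step is drawn between them.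

Compound 3 `COc1ccc(C2=NN(C(C)=O)C(c3ccc(OCc4cn(Cc5ccc([N+](=O)[O-])cc5)nn4)c(OC)c3)C2)cc1` has not yet been measured. It differs from compound 1 in one place: methoxy in place of nitro on an aromatic carbon. Among the measured compounds shown here, no measured pair isolates this change, so no step size is known for it. For the measured compounds named here, a moderate drop from compound 1 to compound 3 in this assay is expected, a number 24 percentage points lower from compound 1 to compound 3 (beyond the scatter), since the only other compound without a nitro on that aryl, compound 2, gives 22%. Compound 3 is therefore estimated at 35%, within a range of 15% to 58%.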

Compound 3, percent growth inhibition at one concentration: 14%
Beside the measured number, compound 3's estimate is 21 percentage points above it; measured number outside the range, below it.
By their numbers in this assay, from the lowest: compounds 3 and 2 (each within the scatter of the next); then compound 1.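

In this assay, among these compounds, the change from 4-nitrophenyl to 4-methoxyphenyl gives a number 45 percentage points lower from compound 1 to compound 3 (beyond the scatter) and is the first step that isolates a single place. With the rest of compound 1 held constant, growth inhibition at the concentration tested clearly depends on which of these two groups sits on this aromatic carbon, para to a large group. No measurement bears on the reason for the fall.

On these data alone, only nitro and methoxy are compared at this place, so it stays open whether the fall reflects the loss of nitro or the arrival of methoxy. An amine, a carboxylic acid or a plain hydrogen on the same carbon would help separate these two readings.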